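This account rests on a few compounds, and the source may have more. Where it says the series, first, only, none or still open, it means among the compounds named here.

Of the compounds shown here, three built on one shared core have been measured in a functional assay on MGC-803 cells (Homo sapiens) for inhibition, read by sulforhodamine B assay; on this read-out lower numbers stand for stronger inhibition and higher numbers for weaker inhibition. Compound 1 `Cc1ccc(NC2=CC(=O)c3nc4n(c3C2=O)[C@H]2OC[C@@H](O)[C@H]2OC4)cc1C` gives 860 nM. Compound 2 `COc1cccc(NC2=CC(=O)c3nc4n(c3C2=O)[C@H]2OC[C@@H](O)[C@H]2OC4)c1` gives 1780 nM, and compound 3 `O=C1C=C(Nc2cccc(F)c2)C(=O)c2c1nc1n2[C@H]2OC[C@@H](O)[C@H]2OC1` gives 2180 nM. Compound 3 thus carries the highest number of the three: its gap to compound 2 is within the scatter, whereas the step of a 2.5-fold higher number from compound 1 to compound 3 (0.40 log units; beyond the scatter) lies beyond it, as does the step of a 2.1-fold higher number from compound 1 to compound 2 (0.32 log units; beyond the scatter). The step of a 1.2-fold higher number from compound 2 to compound 3 (0.09 log units; within the scatter) stays within the scatter.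

Compound 4 `O=C1C=C(N2CCCC2)C(=O)c2c1nc1n2[C@H]2OC[C@@H](O)[C@H]2OC1` has not yet been measured. It differs from compound 3 by pyrrolidin-1-yl in place of (3-fluorophenyl)amino on a double-bonded ring carbon. Among the measured compounds shown here, none of the measured steps bears directly on this change: each of them only exchanges substituents on the aromatic ring while keeping the amine nitrogen and the ring it carries, and those exchanges produced at most modest movements. The present change removes the whole (3-fluorophenyl)amino group, so the measured steps offer no guide to the size or direction of the step, and any estimate must be broad. For compound 4 a number of 3500 nM is expected, within a range from 900 nM to 14000 nM. This expectation means a step of a 1.6-fold higher number from compound 3 to compound 4 (0.21 log units; within the scatter).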

Compound 4, half-maximal inhibitory concentration: > 16000 nM
Compound 4: only a limit was reported; the forecaster's own chance of this, stated with the estimate: 15%; at least 4.5-fold (0.66 log units) between middle value and limit.
By their numbers in this assay, from the lowest: compound 1; then compounds 2 and 3 (each within the scatter of the next). At a limit, above all of these: compound 4.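

In this assay compound 4 gives only a limit of the assay, not a number: the limit of > 16000 nM in this assay, at which 1 of the 4 values shown sits.

Even read as a limit, the result shows that this position responds far more to losing the whole (3-fluorophenyl)amino group than to any exchange on the aromatic ring, since pyrrolidin-1-yl on the double-bonded ring carbon gives an at least 7.3-fold higher number from compound 3 to compound 4 (0.86 log units; beyond the scatter) and an at least 8.9-fold higher number from compound 2 to compound 4 (0.95 log units; beyond the scatter) and also an at least 18-fold higher number from compound 1 to compound 4 (1.26 log units; beyond the scatter). The largest earlier step, a 2.5-fold higher number from compound 1 to compound 3 (0.40 log units; beyond the scatter), kept the amine nitrogen and its aromatic ring in place, so it gave no sign of how much would be lost once both were replaced. The three aromatic amines all stay on the lower side of this limit, which makes the amine carrying an aromatic ring the better-supported arrangement among the four compounds shown.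

The change removes a six-membered aromatic ring and a hydrogen-bond donor together, and these compounds do not tell which of the two matters. A cyclopentylamino group, which keeps the amine hydrogen without the aromatic ring, or an N-methyl-N-phenylamino group, which keeps the aromatic ring without that hydrogen, would pull the two apart.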